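Cytotoxicity notes on three measured compounds and one analogue

The source may hold more compounds than are shown below. What is called first, only, known or untested is meant among the compounds shown, and "the series" means these compounds.

compound 1 `Clc1ccc(NCc2cncn2Cc2ccc(-c3ccccc3)cc2)cc1-c1ccccc1` — in a toxicity assay on NIH3T3 cells (Mus musculus) for cytotoxicity, read by resazurin assay (on this read-out lower numbers stand for an effect already at smaller amounts and higher numbers for an effect only at larger amounts of compound), compound 1 gives only a limit, > 1000 nM.
compound 2 `Clc1ccc(Cn2cncc2CNc2ccc(-c3nc4ccccc4s3)c(-c3ccccc3)c2)cc1` — in this assay compound 2 gives only a limit, > 1000 nM.
compound 3 `COC(=O)c1ccc(NCc2cncn2Cc2cccc(N)c2)cc1-c1ccccc1` — in this assay compound 3 gives only a limit, > 10000 nM.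

None of the three results is a number. Two of them sit at the limit of > 1000 nM in this assay, at which 2 of the 3 values shown sit, while the result for compound 3 sits at the limit of > 10000 nM in this assay, at which 1 of the 3 values shown sits. For the measured compounds named here, compound 3 therefore stands apart only in that its limit was set at a different concentration; no ordering among the three compounds can be read from limits alone, and no step between any pair of them can be given.

Compound 4 `COC(=O)c1ccc(NCc2cncn2Cc2ccc(C)cc2)cc1-c1ccccc1` has not been measured in this assay. Its difference from compound 3 is 4-methylphenyl in place of 3-aminophenyl on a saturated chain carbon bound to an aromatic nitrogen. The shared core, the ester and the pendant phenyl are unchanged.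

Going by the values given here, because no measured step is available, the expectation rests only on the fact that every result so far is a limit. For the change from compound 3 to compound 4, no shift beyond the usual scatter is expected, as a number no higher from compound 3 to compound 4 (the limit leaves the size open) expresses. Compound 4 is thus estimated at 10000 nM in this assay, with a range from 3000 nM to 30000 nM, and most likely again reported only as a limit.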

Compound 4, half-maximal effective concentration: 50000 nM
For compound 4 the middle estimate is 5.0-fold (0.70 log units) below the measured one; measured number above the stated range.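

For the compounds shown here, compound 3 gives only a limit in this assay, > 10000 nM, so no step from compound 3 to compound 4 can be read. The compounds shown leave open whether 4-methylphenyl in place of 3-aminophenyl shifts the result in this assay at all, and how compounds 1, 2 and 3 rank against compound 4.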